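Swapping an amine for a methoxy on a chalcone-like pyrazole

A few compounds are considered here, and "the series" means these few. Any claim that something is new, unique, unknown or untested is made for them only; others in the source may bear on it.

Measured compounds:
- compound 1, `COc1cc(-c2cc(/C=C/C(=O)c3ccc(N)cc3)[nH]n2)cc(OC)c1OC`, -90%
- compound 2, `COc1ccc(-c2cc(/C=C/C(=O)c3ccc(OC)c(OC)c3)[nH]n2)cc1`, -96%
- compound 3, `COc1ccc(-c2cc(/C=C/C(=O)c3ccc(N)cc3)[nH]n2)cc1`, -57%

These three compounds were tested in a functional assay on 786-0 cells (Homo sapiens) for cytotoxicity, read by sulforhodamine B assay, with a stated time of 48 h, tested at 100 uM; on this read-out higher numbers stand for a weaker effect at the one concentration tested and lower numbers for a stronger effect. Compound 1 sits second of the three with -90%; compound 2 gives -96%, a number within the scatter of compound 1, so the two cannot be told apart, while compound 3 gives -57%, which lies beyond the scatter and points to a weaker effect.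

Compound 4, `COc1ccc(C(=O)/C=C/c2cc(-c3cc(OC)c(OC)c(OC)c3)n[nH]2)cc1`, differs from compound 1 in one place: methoxy in place of amino on an aromatic carbon. Cut one bond further out, this is 4-aminophenyl to 4-methoxyphenyl. Among the compounds with values here, no step between two measured compounds differing in only this way is available, so the expectation rests on the shared core and on the values shown. Compound 2, which also carries methoxy groups rather than amino, shows a number close to compound 1, so the step of a number 3 percentage points lower from compound 1 to compound 4 (within the scatter) is expected to be small, within the scatter, and if anything toward a stronger effect. Compound 4 is therefore estimated at -93%, between -100% and -75%.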

Compound 4, a percentage reported as activity, at one concentration (the size of the read-out at that concentration, not a potency): -48%
For compound 4 the middle estimate is 45 percentage points below the measured one; measured number above the stated range.
By their numbers in this assay, from the lowest: compounds 2 and 1 (each within the scatter of the next); then compounds 3 and 4 (each within the scatter of the next).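

In this assay, putting methoxy in place of amino on an aromatic carbon, para to a large group, gives a number 42 percentage points higher from compound 1 to compound 4 (beyond the scatter), so this position is sensitive to the group it carries, and the amino form has the stronger effect at the one concentration tested. This is the only pair shown that isolates the change, and it means the closeness of compound 2 to compound 1 says nothing about this swap taken alone. Nothing measured here explains why the two groups differ so much.

Still open, as far as these compounds go, is whether a hydroxyl, a dimethylamino or an acetamide at this position would behave like amino or like methoxy. From the compounds shown here alone, it is also open whether the same swap would give a step of this size on a different core.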